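The compounds below may be only part of what the source reports. "The series", "measured", "known", "first", "only" and "open" are said of these compounds alone.

The study follows inhibition of rice growth, measured in an ADME assay on the whole organism for inhibition, with Oryza sativa as the target, with a stated time of 7 days; on this read-out lower numbers stand for stronger inhibition and higher numbers for weaker inhibition. Of the compounds shown here, three have been tested so far. Compound 1 `CCC1Oc2ccc(Cl)cc2N(O)C1=O` gives 56000 nM in this assay. Compound 3 `CCC1Oc2ccc(F)cc2N(O)C1=O` differs from compound 1 only by fluoro in place of chloro on an aromatic carbon, and in this assay compound 3 gives 15000 nM. That single change produced a 3.7-fold lower number from compound 1 to compound 3 (0.57 log units; beyond the scatter).

Compound 2 `CCCCC(=O)ON1C(=O)COc2ccc(Cl)cc21` is built on a different core, and the difference between the two cores is not broken down here. In this assay compound 2 gives 2000 nM, the lowest of the three numbers; its gap to compound 3 and its larger gap to compound 1 are both beyond the usual scatter of repeated measurements.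

Compound 4 `CCCCC(=O)ON1C(=O)COc2ccc(F)cc21` has not yet been measured. It differs from compound 2 by fluoro in place of chloro on an aromatic carbon. The place of this change is described in the same words as the change from compound 1 to compound 3, so it is the same change applied to the other core, and the pair of compound 1 and compound 3 is the only other instance of it among the compounds shown. Going by the values given here, the expected step from compound 2 to compound 4 in this assay is a 3.1-fold lower number from compound 2 to compound 4 (0.49 log units; beyond the scatter), an expectation that rests on the single earlier instance, a 3.7-fold lower number from compound 1 to compound 3 (0.57 log units; beyond the scatter), with some allowance for the core being different. On that basis compound 4 is expected to give about 650 nM in this assay. The plausible range for compound 4 is estimated to run from 250 nM to 2000 nM.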

Compound 4, half-maximal inhibitory concentration: 6000 nM
Compound 4: the middle estimate sits 9.2-fold (0.97 log units) below what was measured, and the stated range ends below it.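

In this assay, fluoro in place of chloro on an aromatic carbon of the core of compound 2 gave a 3.0-fold higher number from compound 2 to compound 4 (0.48 log units; beyond the scatter), so the change did not keep the direction it had on the core of compound 1. Set side by side, the two instances of this change run in opposite directions, and the gap between them is larger than repeated measurement would account for: the same change on two cores in this assay, a 3.7-fold lower number (0.57 log units; beyond the scatter) from compound 1 to compound 3 and a 3.0-fold higher number (0.48 log units; beyond the scatter) from compound 2 to compound 4, 11-fold (1.05 log units) apart, beyond the scatter of two such steps. This shows that, among the compounds shown, the step seen on one core cannot simply be carried over to the other, but with only one pair on each core it does not show which difference between the cores separates the two steps, nor how the change would behave on any third core.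

The compounds shown leave open whether the difference between the two steps goes with the pentanoyl ester of compound 2 and compound 4 or with the ethyl group of compound 1 and compound 3, as no compound here carries both or neither. They also leave open how a bromo or methyl group on that same aromatic carbon would behave on either core.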